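Adding a Second Trifluoromethyl Group to Compound 1

This account rests on a few compounds, and the source may have more. Where it says the series, first, only, none or still open, it means among the compounds named here.

For the measured compounds named here, in a functional assay on A549 cells (Homo sapiens) for antiproliferative activity, read by MTT assay, with a stated time of 72 h (a lower number here means a stronger inhibitor, a higher number a weaker inhibitor), compound 1 `O=S1(=O)C=Cc2cccc(Nc3cccc(C(F)(F)F)c3)c21` gives 360 nM and holds the lowest number of the three compounds tested so far. Compound 2 `O=S1(=O)C=Cc2cccc(Nc3ccc(Cl)cc3)c21` stands at 1040 nM and compound 3 `O=S1(=O)C=Cc2cccc(Nc3cccc(F)c3)c21` at 2550 nM with both gaps to compound 1 beyond the usual scatter. Compound 4 `O=S1(=O)C=Cc2cccc(Nc3cc(C(F)(F)F)cc(C(F)(F)F)c3)c21` has not been measured yet. It carries trifluoromethyl in place of hydrogen on an aromatic carbon, meta to a trifluoromethyl group, and trifluoromethyl in place of hydrogen on an aromatic carbon sums up the change.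

Going by the values given here, only one measured step bears on this change. Fluoro in place of trifluoromethyl on an aromatic carbon gave a 7.1-fold higher number from compound 1 to compound 3 (0.85 log units; beyond the scatter) and counts as modest. Among the compounds with values here, that step exchanges one group for another rather than adding a second one, and no measured compound carries two groups on the ring that changes. It therefore offers only a hint that more trifluoromethyl goes with a lower number. A small step in that direction is expected in this assay and may well stay within the scatter. The expected step is a 1.4-fold lower number from compound 1 to compound 4 (0.16 log units; within the scatter) and remains an estimate. Compound 4 is expected at 250 nM with 85 nM to 750 nM as the estimated range.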

Compound 4, half-maximal inhibitory concentration: 3840 nM
The estimate for compound 4 lay 15-fold (1.19 log units) below the measured number; measured number above the stated range.
By their numbers in this assay, from the lowest: compound 1; then compound 2; then compounds 3 and 4 (each within the scatter of the next).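

Placing trifluoromethyl in place of hydrogen on an aromatic carbon, meta to a trifluoromethyl group, gives an 11-fold higher number from compound 1 to compound 4 (1.03 log units; beyond the scatter) in this assay, so this added group goes with a large loss of antiproliferative strength rather than a gain. The earlier compounds shown here each carried a single group on the ring that changes, and among them trifluoromethyl gave the lowest number; compound 4 shows that this lead does not carry over when a second trifluoromethyl group is added at this position. Nothing measured here accounts for the size of this step.

On these data alone, what remains open is whether the loss comes with any added group on this carbon or is specific to trifluoromethyl, a question that a methyl group, an amine or a carboxylic acid at the same place would help to settle. As far as these compounds go, it is also open whether a second trifluoromethyl group would give the same result at another carbon of this ring, or whether the step would keep its size if the first trifluoromethyl group were replaced by chloro or fluoro.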